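This account rests on a few compounds, and the source may have more. Where it says the series, first, only, none or still open, it means among the compounds named here.

Compound 2 `C[C@@H](O)[C@H]1C(=O)N2C(C(=O)OCOC(=O)OC3CCCc4ccccc4C3)=C(S[C@@H]3CN[C@H](C(=O)N(C)C)C3)[C@H](C)[C@H]12` stands level with compound 1 `C[C@@H](O)[C@H]1C(=O)N2C(C(=O)OCOC(=O)OC3Cc4ccccc4C3)=C(S[C@@H]3CN[C@H](C(=O)N(C)C)C3)[C@H](C)[C@H]12` in a physicochemical assay for metabolic stability, read by HPLC, with a stated time of 120 min, at pH 6, tested at 100 uM; a lower number here means that less of the compound is left, a higher number that more of the compound is left: compound 2 gives 96%, and compound 1 gives 96%. A third compound, compound 3 `CC(C)OC(=O)OC(C)OC(=O)C1=C(S[C@@H]2CN[C@H](C(=O)N(C)C)C2)[C@H](C)[C@@H]2[C@@H]([C@@H](C)O)C(=O)N12`, was run more than once in this assay, and compound 3 gives 92%; 94% (2 entries). Compound 4 `C[C@@H](O)[C@H]1C(=O)N2C(C(=O)OCOC(=O)OC3CCc4ccccc4C3)=C(S[C@@H]3CN[C@H](C(=O)N(C)C)C3)[C@H](C)[C@H]12` has not yet been measured in this assay. It differs from compound 2 in one place: a group of 10 heavy atoms (10 carbon; one six-membered non-aromatic ring of carbon only, one six-membered aromatic ring of carbon only) in place of a group of 11 heavy atoms (11 carbon; one six-membered aromatic ring of carbon only, one seven-membered non-aromatic ring of carbon only), on an oxygen next to a carbonyl group. Going by the values given here, only one measured step bears on this change, no change at the digits printed from compound 1 to compound 2 (within the scatter), which exchanged one ring-bearing group for another on the oxygen next to a carbonyl group and left the percent of compound remaining where it was; the several entries of compound 3 the several entries of compound 3 in this assay, 92%; 94% (2 entries) show how closely repeated runs of this assay agree. On that basis compound 4 is expected to show no step beyond the scatter, no change at the digits printed from compound 2 to compound 4 (within the scatter). Compound 4 is accordingly estimated at 96%, with a range from 90% to 99%.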

Compound 4, percent of the compound remaining: 93%
The estimate for compound 4 lay 3 percentage points above the measured number; measured number inside the range.
By their numbers in this assay, from the lowest: compounds 4, 1 and 2 (each within the scatter of the next).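

The six-membered non-aromatic ring of 1,2,3,4-tetrahydronaphthalen-2-yl completes a set of three groups on the oxygen next to a carbonyl group, with a five-, a six- and a seven-membered non-aromatic ring, each alongside a six-membered aromatic ring, and this assay separates none of them beyond the scatter. The exchange of the seven-membered ring group gives a number 3 percentage points lower from compound 2 to compound 4 (within the scatter), and the exchange of 2,3-dihydro-1H-inden-2-yl gives a number 3 percentage points lower from compound 1 to compound 4 (within the scatter). Repeated runs of a single compound also show a spread of their own: the several entries of compound 3 in this assay, 92%; 94% (2 entries)

The compounds shown leave open how the percent of compound remaining would respond to an amine or a carboxylic acid on this group. They also leave open whether a cyclohexyl group, with no aromatic ring, would read the same.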